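Sulfonamide anilides: changing the sulfonamide nitrogen substituent

This account rests on a few compounds, and the source may have more. Where it says the series, first, only, none or still open, it means among the compounds named here.

Measured compounds:
compound 1 `CN(c1ccccc1)S(=O)(=O)c1ccc(NC(=O)c2ccc(Cl)cc2Cl)cc1` 2570 nM
compound 2 `O=C(Nc1ccc(S(=O)(=O)Nc2ccccc2)cc1)c1cc2ccccc2oc1=O` 7760 nM
compound 3 `N#Cc1ccc(C(=O)Nc2ccc(S(=O)(=O)Nc3ccccc3)cc2)c(F)c1` 229 nM

In a functional assay on HEK293 cells for agonist activity at probable G-protein coupled receptor 27 (Homo sapiens), read by a luciferase reporter and beta-arrestin recruitment, with a stated time of 10 min (a lower number here means that less compound is needed, a higher number that more compound is needed for the effect), compound 1 gives 2570 nM, the second highest of the three numbers. Its nearest neighbour is compound 2, which gives 7760 nM, a gap beyond the scatter; compound 3, with 229 nM, sits furthest away, also beyond the scatter. Compound 4 `COc1ccc(NS(=O)(=O)c2ccc(NC(=O)c3ccc(Cl)cc3Cl)cc2)cc1` is not yet measured. Its difference from compound 1 is: (4-methoxyphenyl)amino in place of methyl(phenyl)amino on a sulfonyl sulfur. Among the measured compounds shown here, no measured pair shows this change on its own. The step in this assay is therefore expected to be a small one, estimated as a 1.7-fold lower number from compound 1 to compound 4 (0.23 log units; within the scatter). Compound 4 is accordingly estimated at 1500 nM, with a range from 400 nM to 5000 nM.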

Compound 4, half-maximal effective concentration: > 100000 nM
Compound 4: no number, only a limit; the forecaster's own chance of this, stated with the estimate: 10%; middle value at least 66-fold (1.82 log units) away from the limit.
By their numbers in this assay, from the lowest: compound 3; then compound 1; then compound 2. At a limit, above all of these: compound 4.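

In this assay, (4-methoxyphenyl)amino in place of methyl(phenyl)amino on a sulfonyl sulfur gives an at least 38-fold higher number from compound 1 to compound 4 (1.59 log units; beyond the scatter), the first step read at this position, and it shows that the position does not accept every change. Compound 4 gives no number, only a limit: the limit of > 100000 nM in this assay, at which 1 of the 4 values shown sits.

The step joins two differences, the methyl leaving the sulfonamide nitrogen and the methoxy entering, and the compounds shown do not separate them. Methyl(4-methoxyphenyl)amino or plain phenylamino on the core of compound 1 would tell them apart.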